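Compound 4: an Azido Group Added to Compound 2

The source may report more compounds than this note shows. Statements on the series, on what has been measured and on what is new or still open speak of the compounds shown alone.

Measured so far in an assay on membranes from heart (Canis lupus familiaris) for displacement of a labelled ligand from sulfonylurea receptor 2, Kir6.2 (Homo sapiens); a lower number here means a stronger inhibitor, a higher number a weaker inhibitor:
compound 1 `CCC(C)(C)/N=C(\NC#N)Nc1ccc(S(=O)(=O)N2CCCCC2)cc1` gives > 30000 nM, which is a limit of the assay and not a number;
compound 2 `CCC(C)(C)/N=C(\NC#N)Nc1ccc(I)cc1` gives 74 nM;
compound 3 `CCC(C)(C)/N=C(\NC#N)Nc1ccc(C#N)cc1` gives 160 nM.

Among the two numbers, compound 2 has the lowest; its nearest neighbour is compound 3, reached by a 2.2-fold higher number from compound 2 to compound 3 (0.33 log units; beyond the scatter), the only one-place step among the measured compounds. Compound 1 sits at the limit of > 30000 nM in this assay, at which 1 of the 3 values shown sits, so its value gives no number to compare.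

Compound 4 `CCC(C)(C)/N=C(\NC#N)Nc1ccc(I)c(N=[N+]=[N-])c1` differs from compound 2 by azido in place of hydrogen on an aromatic carbon. Among the measured compounds shown here, none of the measured steps concerns this change: the one step available, a 2.2-fold higher number from compound 2 to compound 3 (0.33 log units; beyond the scatter), swaps the group on the aromatic carbon that carries iodo in compound 2, whereas in compound 4 the iodo stays and an azido group enters where a hydrogen stood. For the measured compounds named here, the measured data therefore say nothing direct about adding an azido group, and the expectation can only lean on the fact that the single measured change at the aromatic ring produced a modest step.

On that basis compound 4 is expected to stay near compound 2, with an estimated step of a 1.5-fold higher number from compound 2 to compound 4 (0.17 log units; within the scatter) in this assay. The estimate for compound 4 in this assay is 110 nM, within a range from 30 nM to 400 nM.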

Compound 4, inhibition constant: 57 nM
Beside the measured number, compound 4's estimate is 1.9-fold (0.29 log units) above it; the measured number falls inside the stated range.
By their numbers in this assay, from the lowest: compounds 4 and 2 (each within the scatter of the next); then compound 3. At a limit, above all of these: compound 1.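

In this assay, azido in place of hydrogen gives a 1.3-fold lower number from compound 2 to compound 4 (0.11 log units; within the scatter), so this aromatic carbon, ortho to an iodo group and meta to a large group, can carry the whole azido group without a step beyond the scatter. The earlier step concerned only the aromatic carbon that carries iodo, whereas this one opens a second place on the ring and keeps the iodo group in position. Nothing in the data shown bears on why the azido group is accepted at this carbon.

The compounds shown leave open whether an amine, a carboxylic acid or a longer chain at this same carbon would be accepted as the azido group is, so a single group cannot yet describe this place on the ring as a whole. They also leave open whether the azido group would give a step of the same size with the cyano group of compound 3 in place of iodo, since here it is seen only ortho to an iodo group.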